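A few compounds are considered here, and "the series" means these few. Any claim that something is new, unique, unknown or untested is made for them only; others in the source may bear on it.

In a functional assay on HeLa cells (Homo sapiens) for inhibition, read by CCK-8 assay, with a stated time of 72 h, tested at 8 uM (a lower number here means less inhibition of growth, a higher number more inhibition of growth at the concentration tested), compound 1 (`Nc1ccccc1NC(=O)/C=C/c1ccc(CSc2cccc(F)c2)cc1`) gives 18.6%, compound 3 (`Nc1ccccc1NC(=O)c1ccc(CSc2ccc(C(F)(F)F)cn2)cc1`) gives 16.5%, and compound 2 (`Nc1ccccc1NC(=O)c1ccc(CSc2cccc(F)c2)cc1`) gives 78.4%. That last value is the highest of the three and lies well beyond the scatter from both others. Compound 4 (`Nc1ccccc1NC(=O)c1ccc(CSc2ccc(Cl)cc2)cc1`) keeps the rest of compound 2 but has 4-chlorophenyl in place of 3-fluorophenyl on a sulfur. Within the data shown here, no measured pair shows this swap alone, so any forecast is loose. Compound 3, which carries a different group on that sulfur, reaches only 16.5%, so a moderate fall is expected. The estimated change is a number 23.4 percentage points lower from compound 2 to compound 4 (beyond the scatter), probably beyond the scatter. For compound 4 the expected value is 55%, within an estimated range of 25% to 82%.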

Compound 4, percent growth inhibition at one concentration: 51.4%
The estimate for compound 4 lay 3.6 percentage points above the measured number; the range from low to high includes it.
By their numbers in this assay, from the lowest: compounds 3 and 1 (each within the scatter of the next); then compound 4; then compound 2.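

In this assay, 4-chlorophenyl in place of 3-fluorophenyl on the sulfur gives a number 27 percentage points lower from compound 2 to compound 4 (beyond the scatter), so two closely related phenyl groups at this position are not interchangeable. Growth inhibition falls but does not vanish: compound 4 gives 51.4% and stays clearly above compound 3 at 16.5% in the same test. Nothing given here explains the fall.

From the compounds shown here alone, both the halogen and its numbered position change in this step, so their separate contributions remain open. A 3-chlorophenyl or 4-fluorophenyl group on that sulfur would pull them apart.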